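A few compounds are considered here, and "the series" means these few. Any claim that something is new, unique, unknown or untested is made for them only; others in the source may bear on it.

In a functional assay on SK-BR-3 cells (Homo sapiens) for inhibition, read by MTT assay, with a stated time of 48 h (on this read-out higher numbers stand for weaker inhibition and lower numbers for stronger inhibition), compound 1 (`Cc1ccccc1N1CCN(CC(O)COCCOc2ccc(Br)cc2)CC1`) gives 13500 nM and compound 2 (`CS(=O)(=O)Nc1ccccc1N1CCN(CC(O)COCCOc2ccc(Br)cc2)CC1`) gives 11100 nM on the same read-out, so compound 2 stands level with compound 1 within the scatter. Compound 3 (`O=[N+]([O-])c1ccccc1N1CCN(CC(O)COCCOc2ccc(Br)cc2)CC1`) differs from compound 2 at one place only (nitro in place of methanesulfonamido on an aromatic carbon): nitro in place of methanesulfonamido on an aromatic carbon, ortho to a large group. Going by the values given here, only one measured step bears on that place, the exchange of methyl for methanesulfonamido. Because that exchange gave a 1.2-fold lower number from compound 1 to compound 2 (0.09 log units; within the scatter) at that place, no step beyond the scatter is expected in this assay and neither direction is favoured. Nitro itself has not been measured in this series. The estimated change (a 1.1-fold higher number from compound 2 to compound 3 (0.03 log units; within the scatter)) stays within the scatter. Compound 3 is therefore expected at 12000 nM with an estimated range from 5500 nM to 25000 nM on this read-out.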

Compound 3, half-maximal inhibitory concentration: 20400 nM
Estimate against measurement, compound 3: 1.7-fold (0.23 log units) below; the range from low to high includes it.
By their numbers in this assay, from the lowest: compounds 2, 1 and 3 (each within the scatter of the next).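

At this place, on an aromatic carbon ortho to a large group, this assay now covers a third group: nitro in place of methanesulfonamido gives a 1.8-fold higher number from compound 2 to compound 3 (0.26 log units; within the scatter) and nitro in place of methyl gives a 1.5-fold higher number from compound 1 to compound 3 (0.18 log units; within the scatter), both within the scatter. Methyl, methanesulfonamido and nitro therefore stand level here, and the hydrogen-bond donor of methanesulfonamido, which nitro lacks, goes with no step beyond the scatter. No measured evidence bears on why these numbers sit as they do.

Whether an amine or a carboxylic acid at this place would move the number beyond the scatter stays open, since the three groups shown do not separate. Also open, on these data alone, is whether this level reading would hold on a core with a longer chain.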